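A few compounds are considered here, and "the series" means these few. Any claim that something is new, unique, unknown or untested is made for them only; others in the source may bear on it.

Compound 1 `Cc1ccc(Cn2cc(CSC(=S)N3CCN(C(=O)OC(C)(C)C)CC3)nn2)cc1`: 17300 nM
Compound 2 `Cc1ccc(-n2cc(CSC(=S)N3CCN(C(=O)OC(C)(C)C)CC3)nn2)cc1`: > 128000 nM
Compound 3 `COc1ccc(Cn2cc(CSC(=S)N3CCN(C(=O)OC(C)(C)C)CC3)nn2)cc1`: > 128000 nM

In a functional assay on PC-3 cells (Homo sapiens) for inhibition, read by MTT assay, with a stated time of 72 h (a higher number here means a weaker inhibitor, a lower number a stronger inhibitor), compound 1 gives 17300 nM. For compound 2 the assay reports only a limit, > 128000 nM. For compound 3 the assay likewise reports only a limit, > 128000 nM. The step of an at least 7.3-fold higher number from compound 1 to compound 2 (0.86 log units; beyond the scatter) and the step of an at least 7.3-fold higher number from compound 1 to compound 3 (0.86 log units; beyond the scatter) are both beyond the scatter, while the step that the two limits leave unreadable from compound 2 to compound 3 cannot be read because both ends are limits. Compound 3 therefore stands at the limit of this assay, a position it shares with compound 2 (the limit of > 128000 nM in this assay, at which 2 of the 3 values shown sit).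

Compound 4 `CC(C)(C)OC(=O)N1CCN(C(=S)SCc2cn(Cc3ccc(Cl)cc3)nn2)CC1` differs from compound 3 in one place: chloro in place of methoxy on an aromatic carbon. For the measured compounds named here, the only measured step that bears on this position is an at least 7.3-fold higher number from compound 1 to compound 3 (0.86 log units; beyond the scatter), which shows that exchanging the group on this aromatic carbon can move the number by at least a modest amount. Whether chloro behaves more like methyl or more like methoxy is not shown by any measured pair. Compound 4 is therefore expected somewhere between the level of compound 1 and the limit, and the estimated step is an at least 3.2-fold lower number from compound 3 to compound 4 (0.50 log units; beyond the scatter). Compound 4 is expected to give about 40000 nM, within a range from 12000 nM to 130000 nM.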

Compound 4, half-maximal inhibitory concentration: > 128000 nM
Compound 4: no number, only a limit; the forecaster's own chance of this, stated with the estimate: 45%; middle value at least 3.2-fold (0.50 log units) from the limit.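

In this assay the reading for compound 4 is only a limit, so chloro in place of methoxy on this aromatic carbon brings no number back, and the steps from compound 2 and from compound 3 to compound 4 cannot be read. Set against methyl, the change can be read, and the result is an at least 7.3-fold higher number from compound 1 to compound 4 (0.86 log units; beyond the scatter). Chloro now stands with methoxy in leaving the number of compound 1 behind, so among the benzyl compounds shown only the methyl group on this carbon gives a number, and the other compounds sit at one limit: the limit of > 128000 nM in this assay, at which 3 of the 4 values shown sit.

The compounds shown leave open whether methyl is singular at this place or whether an ethyl group, a fluoro group or an amine on the same aromatic carbon would also give a number. They also leave open how compound 2, compound 3 and compound 4 rank against one another, and whether a longer chain in place of the benzyl link would change the reading.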